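This account rests on a few compounds, and the source may have more. Where it says the series, first, only, none or still open, it means among the compounds named here.

In an assay on cells with melanin-concentrating hormone receptor 1 (Homo sapiens) as the target, read by radioligand binding (a lower number here means a stronger inhibitor, a higher number a weaker inhibitor), compound 3 `CC(C)C(C)Oc1cccc2ccc(N)nc12` gives 199 nM, the highest of the three numbers shown, though its gap to compound 2 lies within the scatter. Compound 2 `CCC(CC)C(C)Oc1cccc2ccc(N)nc12` gives 191 nM, and compound 1 `Nc1ccc2cccc(OCC3CCCC3)c2n1` gives 53 nM. The two steps leading into compound 3 were a 1.0-fold higher number from compound 2 to compound 3 (0.02 log units; within the scatter) and a 3.8-fold higher number from compound 1 to compound 3 (0.57 log units; beyond the scatter). Compound 4 `CCCC(C)Oc1cccc2ccc(N)nc12` differs from compound 3 by propyl in place of isopropyl on a saturated chain carbon bound to an oxygen on an aromatic ring and a saturated chain carbon. Only the first of those steps sits at this same place, and there the exchange of pentan-3-yl for isopropyl changed nothing beyond the scatter, while the larger step concerned the whole group on the oxygen. The rearrangement in compound 4 is therefore expected to change little, a 1.0-fold higher number from compound 3 to compound 4 (0.00 log units; within the scatter). Compound 4 is estimated at 200 nM, between 100 nM and 400 nM.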

Compound 4, half-maximal inhibitory concentration: 105 nM
The estimate for compound 4 lay 1.9-fold (0.28 log units) above the measured number; the range from low to high includes it.
By their numbers in this assay, from the lowest: compounds 1, 4, 2 and 3 (each within the scatter of the next, the first and the last beyond it).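

In this assay propyl in place of isopropyl gives a 1.9-fold lower number from compound 3 to compound 4 (0.28 log units; within the scatter) and hydrogen in place of ethyl gives a 1.8-fold lower number from compound 2 to compound 4 (0.26 log units; within the scatter) so neither rearranging nor trimming this chain leaves the scatter in these compounds. The new compound also links two ends of the series: 1-methylbutyl in place of cyclopentylmethyl gives a 2.0-fold higher number from compound 1 to compound 4 (0.30 log units; within the scatter) while the earlier step of a 3.8-fold higher number from compound 1 to compound 3 (0.57 log units; beyond the scatter) lay beyond the scatter. Nothing measured here explains these numbers. Still open, from the compounds shown here alone, is how a longer chain such as 1-methylpentyl, or a chain ending in an amine or a carboxylic acid, would read on this oxygen.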